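Removing the butyl group from compound 1

A few compounds are considered here, and "the series" means these few. Any claim that something is new, unique, unknown or untested is made for them only; others in the source may bear on it.

Measured in an ADME assay on HeLa cells (Homo sapiens) for cytotoxicity, read by resazurin assay, with a stated time of 65 h; on this read-out lower numbers stand for an effect already at smaller amounts and higher numbers for an effect only at larger amounts of compound:
- Compound 1 `CCCCc1cc(C(=O)OCC)c(NC(=O)c2ccc([N+](=O)[O-])o2)s1`: > 20000 nM (a limit)
- Compound 2 `CCc1cc(C(N)=O)c(NC(=O)c2ccc([N+](=O)[O-])o2)s1`: > 20000 nM (a limit)
- Compound 3 `CCc1cc(C(=O)O)c(NC(=O)c2ccc([N+](=O)[O-])o2)s1`: > 20000 nM (a limit)

Compound 1 gives no number in this assay, only a limit, and compound 2 and compound 3 likewise give only limits. All that is measured so far is therefore (the limit of > 20000 nM in this assay, at which 3 of the 3 values shown sit).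

Compound 4 `CCOC(=O)c1ccsc1NC(=O)c1ccc([N+](=O)[O-])o1` has hydrogen in place of butyl on an aromatic carbon of the core of compound 1: hydrogen in place of butyl on an aromatic carbon. Going by the values given here, the only measured step is a step that the two limits leave unreadable from compound 2 to compound 3. It is a change at a different place, and its size cannot be read, so it gives no measured size for this change. No step beyond the scatter is expected in this assay, and another limit is the likeliest report because of the limit of > 20000 nM in this assay, at which 3 of the 3 values shown sit. The estimated step is a step that the limit leaves unreadable from compound 1 to compound 4. Compound 4 is expected at 30000 nM, with an estimated range of 10000 nM to 80000 nM.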

Compound 4, half-maximal effective concentration: > 20000 nM
Compound 4 gave a limit, no number; the forecaster's own chance of this, stated with the estimate: 75%; the middle value lies beyond the limit too.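

In this assay compound 4 gives > 20000 nM as a limit and not a number. Going by these compounds alone, compound 1 also gives only a limit, so no step between compound 1 and compound 4 can be read. The compounds shown leave open whether hydrogen in place of butyl changes this read-out at all, because every value is a limit: the limit of > 20000 nM in this assay, at which 4 of the 4 values shown sit.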